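An aromatic ring replaces a saturated one in compound 3

This account rests on a few compounds, and the source may have more. Where it says the series, first, only, none or still open, it means among the compounds named here.

compound 1 `CCCCNC(=O)N1Cc2c(NC(=O)c3ccc(OC)cc3)nn(C(=O)c3ccccc3)c2C1`: 25300 nM
compound 2 `CC(=O)n1nc(NC(=O)c2ccccc2)c2c1CN(C(=O)C1CCC(C)CC1)C2`: 12200 nM

Both compounds were tested in a functional assay on HCT-116 cells (Homo sapiens) for cytotoxicity, read by sulforhodamine B assay, with a stated time of 48 h; a lower number here means a stronger inhibitor, a higher number a weaker inhibitor. Of the two, compound 2 has the lower number, at 12200 nM, while compound 1 stands at 25300 nM. This gap lies just beyond the usual scatter. The two compounds differ in more than one place, so the gap cannot be tied to any single group.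

The next compound, compound 3 `CC(=O)n1nc(NC(=O)c2ccccc2)c2c1CN(C(=O)c1cccc(Cl)c1)C2`, has not yet been measured in this assay. It keeps the rest of compound 2 and changes one group: 3-chlorophenyl in place of 4-methylcyclohexyl on a carbonyl carbon. Here 3-chlorophenyl stands in place of 4-methylcyclohexyl on a carbonyl carbon, whose other neighbour is an amide-type nitrogen in a ring.

Going by the values given here, no measured pair isolates this change, so the expectation starts from compound 2 at 12200 nM. The expected result is a 1.1-fold lower number from compound 2 to compound 3 (0.04 log units; within the scatter), a step that is estimated to stay within the usual scatter, with no firm direction. Compound 3 is expected at 11000 nM, with an estimated range from 4500 nM to 27000 nM.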

Compound 3, half-maximal inhibitory concentration: 17400 nM
Estimate against measurement, compound 3: 1.6-fold (0.20 log units) below; measured number inside the range.
By their numbers in this assay, from the lowest: compounds 2, 3 and 1 (each within the scatter of the next, the first and the last beyond it).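

In this assay, the only single-place comparison shown puts 3-chlorophenyl in place of 4-methylcyclohexyl on a carbonyl carbon and gives a 1.4-fold higher number from compound 2 to compound 3 (0.15 log units; within the scatter), so the two compounds cannot be told apart. At this position, then, a six-membered aromatic ring bearing chlorine and a six-membered non-aromatic ring bearing methyl give readings within the scatter of each other, something the earlier pair could not show because its members differ in more than one place. Nothing available here accounts for this result.

Going by these compounds, whether other groups on this carbonyl carbon would read the same stays open, for instance a plain phenyl, which would separate the ring from its chlorine, a pyridine ring, or a chain ending in an amine. On these data alone, the rest of the shared core also remains untested by any single-place step, so it is unknown whether a carboxylic acid or a morpholine elsewhere on the core would move the number beyond the scatter.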